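Thiazole and benzamide swaps on a sulfonylurea piperidine

The compounds below may be only part of what the source reports. "The series", "measured", "known", "first", "only" and "open" are said of these compounds alone.

Compound 1 `CC(=O)NCCC1CCN(S(=O)(=O)NC(=O)NC[C@@H]2C[C@@H]3C=C[C@@H]2C3)CC1` gives 25% in a functional assay on the whole organism (blood) with Rattus norvegicus as the target, with stated times of 24 h and 1 h, at a dose of 15 mg/kg by the intraperitoneal route; a higher number here means a stronger effect of the compound at the dose given, a lower number a weaker effect.
Compound 2 `O=C(NC[C@@H]1C[C@@H]2C=C[C@@H]1C2)NS(=O)(=O)N1CCC(CCNC(=O)c2cscn2)CC1` gives 37% in this assay.
Compound 3 `Cn1cc(C(=O)NCCC2CCN(S(=O)(=O)NC(=O)NC3CCCCC3)CC2)c(=O)n(C)c1=O` gives 15% in this assay.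

Compound 3 holds the lowest of the three numbers, though its gap to compound 1 lies within the scatter; only its gap to compound 2 lies beyond it. Compound 4 `CSc1ccc(C(F)(F)F)cc1C(=O)NCCC1CCN(S(=O)(=O)NC(=O)NC2CCCCC2)CC1` differs from compound 3 in one place: a group of 12 heavy atoms (8 carbon, 3 fluorine, 1 sulfur; one six-membered aromatic ring of carbon only) in place of a group of 10 heavy atoms (6 carbon, 2 nitrogen, 2 oxygen; one six-membered aromatic ring with 2 hetero atoms), on a carbonyl carbon. Among the compounds with values here, the single measured step at a carbonyl carbon, a number 12 percentage points higher from compound 1 to compound 2 (beyond the scatter), put a 1,3-thiazol-4-yl in place of methyl and raised the read-out modestly. That step sits on a different urea substituent, so it guides only loosely. A modest rise, a number 15 percentage points higher from compound 3 to compound 4 (beyond the scatter), is therefore expected. Compound 4 is estimated at 30%, within 10% to 55%.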

Compound 4, a percentage reported as activity, at one dose (the size of the read-out at that dose, not a potency): 24%
Compound 4: the middle estimate sits 6 percentage points above what was measured; the measured number falls inside the stated range.
By their numbers in this assay, from the lowest: compounds 3, 4 and 1 (each within the scatter of the next); then compound 2.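

With the rest of the molecule held fixed in this assay, placing a six-membered aromatic ring of carbon only, with fewer hydrogen-bond acceptors, on the carbonyl carbon in place of one with 2 hetero atoms gave a number 9 percentage points higher from compound 3 to compound 4 (within the scatter). At this position, two quite different aromatic groups therefore could not be told apart by this read-out. No evidence is available to account for this result. Still open, as far as these compounds go, is whether a 1,3-thiazol-4-yl group on this same urea substituent would separate from either group. Also open, from the compounds shown here alone, is how a simple amine or a carboxylic acid would read here.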